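The source may report more compounds than this note shows. Statements on the series, on what has been measured and on what is new or still open speak of the compounds shown alone.

Compound 1 `CC1CCN(c2c(S(=O)(=O)c3ccc(Cl)cc3)cnc3cc(Cl)ccc23)CC1`: 91% in an assay on isolated protein for displacement of a labelled ligand from metabotropic glutamate receptor 5 (Homo sapiens), with a stated time of 60 min, tested at 1 uM; on this read-out lower numbers stand for less inhibition and higher numbers for more inhibition at the one concentration tested (going by the name of the read-out)
Compound 2 `CC1CCN(c2c(S(=O)(=O)c3ccc(Cl)cc3)cnc3cc(F)ccc23)CC1`: 90% in this assay
Compound 3 `CC1CCN(c2c(S(=O)(=O)c3ccc(F)c(Cl)c3)cnc3cc(F)ccc23)CC1`: 94% in this assay

In this assay compound 1 holds the second highest of the three numbers; the gap to compound 2 is a number 1 percentage points lower from compound 1 to compound 2 (within the scatter), and the gap to compound 3 is within the scatter as well. Compound 4 `CC1CCN(c2c(S(=O)(=O)c3cccc(Cl)c3)cnc3cc(Cl)ccc23)CC1` differs from compound 1 in one place: 3-chlorophenyl in place of 4-chlorophenyl on a sulfonyl sulfur. For the measured compounds named here, the one measured step that changes the ring on the sulfonyl sulfur is a number 4 percentage points higher from compound 2 to compound 3 (within the scatter), too small to count. The three measured compounds sit close together, so no step beyond the scatter is expected from compound 1 to compound 4, and the estimated step is a number 5 percentage points lower from compound 1 to compound 4 (within the scatter). Compound 4 is therefore expected to give about 86% in this assay, within a range from 70% to 96%.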

Compound 4, a percentage reported as inhibition, at one concentration (the size of the read-out at that concentration, not a potency): 92%
Estimate against measurement, compound 4: 6 percentage points below, within the range that was stated.
By their numbers in this assay, from the lowest: compounds 2, 1, 4 and 3 (each within the scatter of the next).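

In this assay, 3-chlorophenyl in place of 4-chlorophenyl on the sulfonyl sulfur gives a number 1 percentage points higher from compound 1 to compound 4 (within the scatter), so this read-out does not separate these two placements of the chlorine. The earlier change at this sulfur added a second halogen to the ring, whereas this one keeps the same atoms and joins them differently. Nothing measured here offers a reason for this result. Still open, as far as these compounds go, is what a methoxy group or a carboxylic acid on this ring would do. A single concentration also gives no potency, so any differences in potency among these compounds remain unknown.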